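The source may hold more compounds than are shown below. What is called first, only, known or untested is meant among the compounds shown, and "the series" means these compounds.

Measured compounds:
compound 1 `COc1ccc(C(=O)/C=C/c2cc(OC)c(OC)c(OC)c2)cc1[N+](=O)[O-]`: in a functional assay on B16 cells (Mus musculus) for cytotoxicity, read by MTT assay, with a stated time of 3 days (on this read-out higher numbers stand for weaker inhibition and lower numbers for stronger inhibition), a limit of the assay, > 100000 nM
compound 2 `COc1ccc(C(=O)/C=C/c2cc(OC)c(OC)c(OC)c2)cc1N`: in this assay 67000 nM
compound 3 `COc1ccc(OC)c(C(=O)/C=C/c2ccc([N+](=O)[O-])cc2)c1`: in this assay a limit of the assay, > 100000 nM

From compound 1 to compound 2 the change is amino in place of nitro on an aromatic carbon, and it gives an at least 1.4-fold lower number from compound 1 to compound 2 (0.17 log units; that floor lies within the scatter). The floor of that step follows from the limit of > 100000 nM in this assay, at which 2 of the 3 values shown sit, where compound 1 sits. Compound 3 is the other compound at that limit. How the core of compound 3 differs from the core of compound 1 is not broken down here.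

Compound 4 `COc1ccc(OC)c(C(=O)/C=C/c2ccc(N)cc2)c1` is not yet measured. It carries amino in place of nitro on an aromatic carbon. For the measured compounds named here, this is the same kind of change as the one from compound 1 to compound 2, not the same: there the amino sits ortho to a methoxy group and meta to a large group, here para to a large group.

Going by the values given here, for the step from compound 3 to compound 4 in this assay the expectation is an at least 1.4-fold lower number from compound 3 to compound 4 (0.15 log units; that floor lies within the scatter), placed beside the earlier step, and it rests on the single measured instance because an at least 1.4-fold lower number from compound 1 to compound 2 (0.17 log units; that floor lies within the scatter) has a floor that lies within the scatter. Compound 4 is expected at 70000 nM, between 30000 nM and 150000 nM.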

Compound 4, half-maximal inhibitory concentration: > 100000 nM
Compound 4: only a limit was reported (the forecaster's own chance of this, stated with the estimate: 45%); middle value at least 1.4-fold (0.15 log units) from the limit.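

In this assay, compound 3 and compound 4 both stand at the limit, so no step can be read for amino in place of nitro between them: the limit of > 100000 nM in this assay, at which 3 of the 4 values shown sit.

The compounds shown leave open where compound 1, compound 3 and compound 4 lie beyond that limit, and whether this change acts alike on both cores.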